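Swapping a Fluorophenyl for a Nitrophenyl: Expected Tolerance

This account rests on a few compounds, and the source may have more. Where it says the series, first, only, none or still open, it means among the compounds named here.

Measured so far:
compound 1, `N/C(=N/NC(CC(=O)c1ccc(-n2ccnc2)cc1)c1cccc(F)c1)c1ccccn1`: 26500 nM
compound 2, `N/C(=N/NC(CC(=O)c1ccc(-n2ccnc2)cc1)c1ccccc1Br)c1ccccn1`: 29000 nM

Both values come from an ADME assay on Vero cells (Chlorocebus sabaeus) for cytotoxicity, read by MTT assay, with a stated time of 72 h; a lower number here means that less compound is tolerated, a higher number that more compound is tolerated. Compound 1 and compound 2 differ in one place, and the step of a 1.1-fold higher number from compound 1 to compound 2 (0.04 log units; within the scatter) shows that this change made no difference beyond the scatter; the two sit together, neither apart from the other.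

Compound 3, `N/C(=N/NC(CC(=O)c1ccc(-n2ccnc2)cc1)c1ccc([N+](=O)[O-])cc1)c1ccccn1`, has not yet been measured in this assay. Its change from compound 1 is 4-nitrophenyl in place of 3-fluorophenyl on a saturated chain carbon bound to an amine nitrogen and a saturated chain carbon. Within the data shown here, the only step at the same place is a 1.1-fold higher number from compound 1 to compound 2 (0.04 log units; within the scatter), which stayed within the scatter, so a step of no more than the scatter is expected here too, that is a 1.0-fold lower number from compound 1 to compound 3 (0.01 log units; within the scatter). Compound 3 is therefore expected to give 26000 nM, between 12000 nM and 55000 nM.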

Compound 3, half-maximal cytotoxic concentration: 23100 nM
Beside the measured number, compound 3's estimate is 1.1-fold (0.05 log units) above it, within the range that was stated.
By their numbers in this assay, from the lowest: compounds 3, 1 and 2 (each within the scatter of the next).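

In this assay, 4-nitrophenyl on a saturated chain carbon bound to an amine nitrogen and a saturated chain carbon stays within the scatter of both earlier groups (a 1.1-fold lower number from compound 1 to compound 3 (0.06 log units; within the scatter)) and (a 1.3-fold lower number from compound 2 to compound 3 (0.10 log units; within the scatter)). The earlier pair showed this only for 3-fluorophenyl and 2-bromophenyl, whereas this third aromatic ring carries a nitro group, with its nitrogen and oxygen atoms, and tolerance still does not separate. No available evidence explains this result.

Still open, as far as these compounds go, is whether an amine or a carboxylic acid in place of the aromatic ring would shift tolerance beyond the scatter.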